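From an Amino Group to a Methoxy Group: Compound 4

The compounds below may be only part of what the source reports. "The series", "measured", "known", "first", "only" and "open" are said of these compounds alone.

Three measured compounds share one core and differ only in the methoxy groups on one of their aromatic rings. Compound 1 `COc1cc(-c2cc(/C=C/C(=O)c3ccc(N)cc3)[nH]n2)cc(OC)c1OC` carries three methoxy groups there; in a functional assay on OVCAR-4 cells (Homo sapiens) for inhibition, read by sulforhodamine B assay, with a stated time of 48 h (on this read-out lower numbers stand for stronger inhibition of growth and higher numbers for weaker inhibition of growth), compound 1 gives 1400 nM. Compound 2 `COc1ccc(-c2cc(/C=C/C(=O)c3ccc(N)cc3)[nH]n2)cc1OC` gives 2680 nM, and compound 3 `COc1ccc(-c2cc(/C=C/C(=O)c3ccc(N)cc3)[nH]n2)cc1` gives 1080 nM. Among these three numbers compound 1 stands second highest, with compound 3 nearest and compound 2 furthest, both differences within the scatter. The two measured steps, a 1.9-fold higher number from compound 1 to compound 2 (0.28 log units; within the scatter) and a 2.5-fold lower number from compound 2 to compound 3 (0.39 log units; beyond the scatter), each remove one methoxy group from that ring and stay small.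

Compound 4 `COc1ccc(C(=O)/C=C/c2cc(-c3cc(OC)c(OC)c(OC)c3)n[nH]2)cc1` keeps the three methoxy groups of compound 1 and changes the other ring: methoxy in place of amino on an aromatic carbon. Among the measured compounds shown here, neither measured step touches this ring, so they show only that single small changes on this core have moved the number by little. The expected step is therefore small, in no known direction, and probably within the scatter. Compound 4 is estimated at 1500 nM, with a range from 500 nM to 4500 nM, which means an expected step of a 1.1-fold higher number from compound 1 to compound 4 (0.03 log units; within the scatter).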

Compound 4, concentration for 50% growth inhibition: 2200 nM
Compound 4: middle estimate off by 1.5-fold (0.17 log units), on the low side, and the stated range covers the measured number.
By their numbers in this assay, from the lowest: compounds 3, 1, 4 and 2 (each within the scatter of the next, the first and the last beyond it).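

Among the compounds shown here, the earlier steps changed only the methoxy groups on the other ring, so this is the first view of the position para to a large group, where 4-aminophenyl becomes 4-methoxyphenyl and this assay shows a 1.6-fold higher number from compound 1 to compound 4 (0.20 log units; within the scatter). On this read-out, then, the amino group at this position is not required for a number of this size, since a methoxy group there gives a value within the scatter. Nothing measured here speaks to the cause of this result.

As far as these compounds go, it remains open whether this position accepts many groups or only these two, which a hydroxyl group, a fluorine atom, a carboxylic acid or a longer chain such as ethoxy at the same place could show. From the compounds shown here alone, it also remains open whether the same change gives so small a step with the methoxy groups of compound 2 or compound 3 on the other ring.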